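Swapping an amide for a sulfonamide on a shared chain

The source may hold more compounds than are shown below. What is called first, only, known or untested is meant among the compounds shown, and "the series" means these compounds.

Of the compounds shown here, three have been measured in a functional assay on CHO-K1 cells for antagonist activity at Urotensin-2 receptor (Rattus norvegicus), read by FLIPR and calcium flux, with a stated time of 1 h; a lower number here means a stronger inhibitor, a higher number a weaker inhibitor. Compound 1 `COc1cc(Br)c(S(=O)(=O)Nc2ccc(C(F)(F)F)c(O[C@@H]3CCN(C)C3)c2)cc1OC` gives 34 nM. Compound 2 `CCN1CCN(c2cccc3c2C(=O)N([C@H](CCCNS(=O)(=O)c2cn(C)c(C)n2)c2ccc(OC)c(OC)c2)C3=O)CC1` gives 140 nM. Compound 3 `CCN1CCN(c2cccc3c2CN([C@H](CCCNC(=O)c2c(C)n[nH]c2C)c2ccc(OC)c(OC)c2)C3=O)CC1` gives 16 nM, the lowest number of the three and therefore the strongest inhibitor among them; its gaps to compound 1 and to compound 2 both lie beyond the usual scatter.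

Compound 4 `CCN1CCN(c2cccc3c2CN([C@H](CCCNS(=O)(=O)c2c[nH]cn2)c2ccc(OC)c(OC)c2)C3=O)CC1` has not yet been measured. It differs from compound 3 in one place: (1H-imidazol-4-yl)sulfonyl in place of (3,5-dimethyl-1H-pyrazol-4-yl)carbonyl on an amine nitrogen. Going by the values given here, no measured pair shows exactly this change. Compound 2 carries a related sulfonyl group on a different core and its value of 140 nM is higher than that of compound 3, but the core also differs, so the two effects cannot be separated.

The step from compound 3 to compound 4 is expected to be a modest loss, a 2.5-fold higher number from compound 3 to compound 4 (0.40 log units; beyond the scatter), in this assay. Compound 4 is therefore estimated at 40 nM, with a likely range from 12 nM to 130 nM.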

Compound 4, half-maximal inhibitory concentration: 23 nM
Compound 4: middle estimate off by 1.7-fold (0.24 log units), on the high side, within the range that was stated.
By their numbers in this assay, from the lowest: compounds 3, 4 and 1 (each within the scatter of the next, the first and the last beyond it); then compound 2.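

On the amine nitrogen of the shared chain, (1H-imidazol-4-yl)sulfonyl can stand in place of (3,5-dimethyl-1H-pyrazol-4-yl)carbonyl with a 1.4-fold higher number from compound 3 to compound 4 (0.16 log units; within the scatter) in this assay, so this assay does not tell the two compounds apart. Going by these compounds alone, this is the first pair on one core, and it shows that this position accepts a sulfonyl link as well as a carbonyl link, at least with these two rings attached. No measurement here explains why the exchange is tolerated.

The step changes the link and the ring together, so the contribution of each cannot be separated. From the compounds shown here alone, a (1H-imidazol-4-yl)carbonyl group or a (3,5-dimethyl-1H-pyrazol-4-yl)sulfonyl group on the same nitrogen would pull the two apart, and the effect of a longer chain also remains open.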